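This account rests on a few compounds, and the source may have more. Where it says the series, first, only, none or still open, it means among the compounds named here.

The measured compounds, all in a functional assay on HeLa cells (Homo sapiens) for antiproliferative activity, with a stated time of 24 h; a lower number here means a stronger inhibitor, a higher number a weaker inhibitor:

Compound 1 `Cc1ccc(C(=O)Nc2sc3c(c2C(N)=O)CCN(Cc2ccc(Cl)cc2Cl)C3)cc1` gives > 50000 nM, which is a limit of the assay and not a number.
Compound 2 `NC(=O)c1c(NC(=O)c2cccc([N+](=O)[O-])c2)sc2c1CCN(Cc1ccc(Cl)cc1Cl)C2` gives 33000 nM.
Compound 3 `Cc1ccc(C(=O)Nc2sc3c(c2C(N)=O)CCN(C(=S)Nc2cc(C(F)(F)F)cc(C(F)(F)F)c2)C3)cc1` gives 17100 nM.

Compounds 1 and 2 share one core, and compound 3 carries another; the difference between the core of compound 1 and the core of compound 3 is not broken down here. Within the first pair one change was made, (3-nitrophenyl in place of 4-methylphenyl on a carbonyl carbon), and it gave an at least 1.5-fold lower number from compound 1 to compound 2 (0.18 log units; that floor lies within the scatter). Only a floor can be read for that step because compound 1 sits at the limit of > 50000 nM in this assay, at which 1 of the 3 values shown sits. The values of compound 2 and compound 3 lie within the usual scatter of each other, so no order between them is claimed.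

Compound 4 `NC(=O)c1c(NC(=O)c2cccc([N+](=O)[O-])c2)sc2c1CCN(C(=S)Nc1cc(C(F)(F)F)cc(C(F)(F)F)c1)C2` has not yet been measured in this assay. It stands to compound 3 as compound 2 stands to compound 1: 3-nitrophenyl in place of 4-methylphenyl on a carbonyl carbon, at the same place in both cases. The expectation for compound 4 is a step of about a 1.7-fold lower number from compound 3 to compound 4 (0.23 log units; within the scatter), resting on an at least 1.5-fold lower number from compound 1 to compound 2 (0.18 log units; that floor lies within the scatter) and on the fact that the earlier step is only a floor set by the limit of > 50000 nM in this assay, at which 1 of the 3 values shown sits. The estimate for compound 4 in this assay is therefore 10000 nM, with a range from 4000 nM to 25000 nM.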

Compound 4, half-maximal inhibitory concentration: 27200 nM
Compound 4: the middle estimate sits 2.7-fold (0.43 log units) below what was measured; the measured number lies above the stated range.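

In this assay, 3-nitrophenyl in place of 4-methylphenyl on a carbonyl carbon, on the core of compound 3, gives a 1.6-fold higher number from compound 3 to compound 4 (0.20 log units; within the scatter). On this core, then, the change has no effect that can be told from the scatter, and the earlier step on the core of compound 1 cannot be set firmly against it, so the data neither show that the change carries from one core to the other nor show that it fails to: the same change on two cores in this assay, an at least 1.5-fold lower number (0.18 log units; that floor lies within the scatter) from compound 1 to compound 2 and a 1.6-fold higher number (0.20 log units; within the scatter) from compound 3 to compound 4; the limit leaves it open whether they differ. On these data alone, the earlier step is a floor and not a full size, so its true extent stays unknown, and that holds the comparison open: the limit of > 50000 nM in this assay, at which 1 of the 4 values shown sits.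

The compounds shown leave open whether an amine or a carboxylic acid on the phenyl ring, or a longer alkyl chain in place of that ring on the carbonyl carbon, would give values that stand clear of the scatter on either core. They also leave open whether any group at this place would move the numbers on both cores in the same way, since the only change shown here is this single exchange of two aryl groups.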